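Notes on a bromo to methyl swap

The source may report more compounds than this note shows. Statements on the series, on what has been measured and on what is new or still open speak of the compounds shown alone.

Measured in a functional assay (muscle tissue) with Cavia porcellus as the target; on this read-out higher numbers stand for an effect only at larger amounts of compound and lower numbers for an effect already at smaller amounts:
- compound 1 `COC(=O)C1=C(C)N=C(C)/C(=C(\O)OC)C1c1ccc(I)cc1`: 22900 nM
- compound 2 `COC(=O)C1=C(C)N=C(C)/C(=C(\O)OC)C1c1cccc(Br)c1`: 1.29 nM

Compound 2 holds the lower number of the two. The next compound is compound 3 `COC(=O)C1=C(C)N=C(C)/C(=C(\O)OC)C1c1cccc(C)c1`, with methyl in place of bromo on an aromatic carbon. Within the data shown here, only one measured step exists, an 18000-fold lower number from compound 1 to compound 2 (4.25 log units; beyond the scatter), and it changes both the halogen and its place, so it bears only loosely on this swap. With compound 2 at 1.29 nM, a moderate move to a higher number in this assay is expected, far smaller than that step. The estimated step is a 9.3-fold higher number from compound 2 to compound 3 (0.97 log units; beyond the scatter). For compound 3 the expected value is 12 nM, with an estimated range of 2 nM to 70 nM.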

Compound 3, half-maximal effective concentration: 110 nM
Estimate against measurement, compound 3: 9.2-fold (0.96 log units) below; measured number outside the range, above it.
By their numbers in this assay, from the lowest: compound 2; then compound 3; then compound 1.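

In this assay the change from 3-bromophenyl to 3-methylphenyl gives a clear loss (an 85-fold higher number from compound 2 to compound 3 (1.93 log units; beyond the scatter)), so this position tells bromo from methyl although each is one heavy atom. Yet 3-methylphenyl in place of 4-iodophenyl still gives a large gain (a 210-fold lower number from compound 1 to compound 3 (2.32 log units; beyond the scatter)), so the low numbers at this place do not rest on bromo alone. No measurement shown here accounts for the gap between bromo and methyl.

Open, going by these compounds, is how chloro or methoxy would read at this same place. Also open, on these data alone, is whether the high number of compound 1 comes from iodo itself or from where it sits on the ring.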